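Swapping Chloro for Methyl on the Aryl Ring

A few compounds are considered here, and "the series" means these few. Any claim that something is new, unique, unknown or untested is made for them only; others in the source may bear on it.

Compound 1 `O/N=C(\CCN1CCN(c2ccccn2)CC1)c1ccccc1Cl`: in a functional assay on HEK293 cells with D(4) dopamine receptor (Homo sapiens) as the target, read by FLIPR (on this read-out higher numbers stand for an effect only at larger amounts of compound and lower numbers for an effect already at smaller amounts), compound 1 gives 24 nM.
Compound 2 `Cc1ccccc1/C(CCN1CCN(c2ccccn2)CC1)=N/O`: in this assay compound 2 gives 4.2 nM.
Compound 3 `O/N=C(\CCN1CCN(c2ccccn2)CC1)c1cccc(Cl)c1`: in this assay compound 3 gives 11.9 nM.

All three compounds share one core and differ only in the aryl group attached to the carbon with a double bond to nitrogen. Compound 1 and compound 3 have the same atoms joined differently: 3-chlorophenyl in place of 2-chlorophenyl on a carbon with a double bond to nitrogen. That rearrangement gives a 2.0-fold lower number from compound 1 to compound 3 (0.30 log units; within the scatter), so the two values cannot be told apart here. Compound 2 carries a different substituent on the same ring: methyl in place of chloro on an aromatic carbon. This produced a 5.7-fold lower number from compound 1 to compound 2 (0.76 log units; beyond the scatter). Between compound 2 and compound 3 the step is a 2.8-fold higher number from compound 2 to compound 3 (0.45 log units; beyond the scatter).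

Compound 4 `Cc1cccc(/C(CCN2CCN(c3ccccn3)CC2)=N/O)c1` has not been measured. It differs from compound 3 in one spot: methyl in place of chloro on an aromatic carbon. Going by the values given here, this is the same kind of change as the one from compound 1 to compound 2, not the same change, since the place differs: there the carbon was ortho to a large group, here it is meta to a large group. Among the compounds with values here, only one earlier example exists, so the expectation is loose. A step of roughly a 2.4-fold lower number from compound 3 to compound 4 (0.38 log units; beyond the scatter) is expected, somewhat smaller than the earlier one; this rests on the step of a 5.7-fold lower number from compound 1 to compound 2 (0.76 log units; beyond the scatter). Compound 4 is therefore expected to give about 5 nM in this assay. For compound 4 the estimate is expected to span 2 nM to 15 nM.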

Compound 4, half-maximal effective concentration: 2.3 nM
Beside the measured number, compound 4's estimate is 2.2-fold (0.34 log units) above it; the measured number falls inside the stated range.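

In this assay, methyl in place of chloro on the ring carbon meta to a large group gives a 5.2-fold lower number from compound 3 to compound 4 (0.71 log units; beyond the scatter), and this step matches the earlier one made on the 2-chlorophenyl compound: the same change on two cores in this assay, a 5.7-fold lower number (0.76 log units; beyond the scatter) from compound 1 to compound 2 and a 5.2-fold lower number (0.71 log units; beyond the scatter) from compound 3 to compound 4, 1.1-fold (0.04 log units) apart, within the scatter of two such steps. In this small set the change therefore kept its size when it went from the 2-chlorophenyl compound to the 3-chlorophenyl compound; moving the methyl group alone gives a 1.8-fold lower number from compound 2 to compound 4 (0.26 log units; within the scatter), while going from 2-chlorophenyl to 3-methylphenyl gives a 10-fold lower number from compound 1 to compound 4 (1.02 log units; beyond the scatter). Going by these compounds alone, these are only two pairs, read in one assay and differing only in where the substituent sits, so they do not show that the change would hold its size at other ring positions, on a different shared core, or on any other read-out, and they do not explain why methyl and chloro differ.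

From the compounds shown here alone, only chloro and methyl appear on the ring here, so it remains open whether a methoxy group or a fluoro group in the same places would follow the same course. Going by these compounds, it is also open whether the step would keep its size if the chain in the shared core were longer.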